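This account rests on a few compounds, and the source may have more. Where it says the series, first, only, none or still open, it means among the compounds named here.

Compound 1 `CC#C[C@@H](CC(=O)O)c1ccc(OCc2ccc3nc(-c4ccc(OC(F)F)cc4)nn3c2)cc1`: 142%
Compound 2 `CC#C[C@@H](CC(=O)O)c1ccc(OCc2ccc3nc(-c4ccc(OCCOC)cc4)nn3c2)cc1`: 133%

Among the compounds with values here, in an assay on cells for agonist activity at Free fatty acid receptor 1 (Rattus norvegicus), read by a beta-galactosidase reporter and beta-arrestin recruitment, with a stated time of 90 min, in the presence of a further agent that is not named here (on this read-out higher numbers stand for larger maximal responses and lower numbers for smaller maximal responses), compound 2 stands lowest of the two numbers, with compound 1 nearest, the only measured step being a number 9 percentage points lower from compound 1 to compound 2 (within the scatter). Compound 3 `CC#C[C@@H](CC(=O)O)c1ccc(OCc2ccc3nc(-c4ccc(C#N)cc4)nn3c2)cc1` carries the change (cyano in place of 2-methoxyethoxy on an aromatic carbon), on the same aromatic carbon that the earlier step altered. Within the data shown here, no measured step covers a cyano group, so the expectation leans only on that earlier swap, which stayed within the scatter. The step to compound 3 is therefore expected to be small, a number 2 percentage points higher from compound 2 to compound 3 (within the scatter). Compound 3 is estimated at 135%, within 105% to 160%.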

Compound 3, largest response reached (reported as percent of maximum), in percent of the reference or control that the assay uses: 125%
The estimate for compound 3 lay 10 percentage points above the measured number; the measured number falls inside the stated range.
By their numbers in this assay, from the lowest: compounds 3, 2 and 1 (each within the scatter of the next, the first and the last beyond it).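

Cyano at this aromatic carbon gives the first single change here whose step lies beyond the scatter in this assay (a number 17 percentage points lower from compound 1 to compound 3 (beyond the scatter)), with cyano in place of difluoromethoxy. Against 2-methoxyethoxy the same group gives a step within the scatter (a number 8 percentage points lower from compound 2 to compound 3 (within the scatter)), so the outcome of placing cyano here depends on which compound it is compared with. Nothing measured here accounts for either step.

From the compounds shown here alone, whether an amine, a carboxylic acid or a longer chain at this carbon would keep the maximal response remains open. So does whether these steps would hold on a different core.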